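Chain unsaturation in a chromone series: antiproliferative notes

The compounds below may be only part of what the source reports. "The series", "measured", "known", "first", "only" and "open" are said of these compounds alone.

Compound 1 `CCCCCCCCCCCCCCCc1cc(=O)c2c(O)c(C)c(OCOC)cc2o1` carries a saturated chain on one core; compound 2 `CCCCC/C=C\C/C=C\CCCCCCCc1cc(=O)c2c(O)c(C)c(OCOC)cc2o1` carries the unsaturated chain on that same core. Compound 3 `CCCCCCCCCCCCCCCc1cc(=O)c2c(O)c(C)c(O)c(C)c2o1` puts the saturated chain on a second core, and compound 4 `CCCCC/C=C\C/C=C\CCCCCCCc1cc(=O)c2c(O)c(C)c(O)c(C)c2o1` puts the unsaturated chain on that second core. The difference between the two cores is not broken down here.

In a functional assay on MCF7 cells (Homo sapiens) for antiproliferative activity, read by MTT assay (a higher number here means a weaker inhibitor, a lower number a stronger inhibitor), compound 1 gives only a limit, > 67200 nM. Compound 2 likewise gives only a limit in this assay, > 67200 nM. Compound 3 also reaches only a limit in this assay, > 67200 nM. The change from compound 1 to compound 2 is deca-1,4-dien-1-yl in place of octyl on a saturated chain carbon, seven bonds along the chain from an aromatic carbon. The step that the two limits leave unreadable from compound 1 to compound 2 cannot be sized because the limit of > 67200 nM in this assay, at which 3 of the 3 values shown sit, leaves both ends of it at the same limit.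

The change from compound 3 to compound 4 is deca-1,4-dien-1-yl in place of octyl on a saturated chain carbon, seven bonds along the chain from an aromatic carbon, the same change at the same place as the one made on the first core. Among the compounds shown it occurs twice, and the one measured instance gives no readable size. For compound 4 the step is expected to be a step that the limit leaves unreadable from compound 3 to compound 4. This expectation rests on (the limit of > 67200 nM in this assay, at which 3 of the 3 values shown sit), which shows every measured value of the series at the same limit in this assay. Compound 4 is therefore estimated at 90000 nM, with an expected range from 30000 nM to 300000 nM, and most probably this assay will again report only a limit for compound 4.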

Compound 4, half-maximal inhibitory concentration: > 84100 nM
Compound 4: no number, only a limit (the forecaster's own chance of this, stated with the estimate: 85%); the middle value lies beyond the limit too.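

In this assay compound 4 gives only a limit, > 84100 nM. Compound 3 also stands at a limit, so no size can be read for the change between compound 3 and compound 4. The compounds shown leave open whether deca-1,4-dien-1-yl in place of octyl alters antiproliferative activity on either core, and how the two cores compare, since none gives a number in this assay.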